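The source may hold more compounds than are shown below. What is called first, only, known or untested is meant among the compounds shown, and "the series" means these compounds.

In an assay on the whole organism (plasma, strain Sprague-Dawley) for inhibition of Dipeptidyl peptidase 4 (Rattus norvegicus), with a stated time of 6 h, at a dose of 1 mg/kg by the oral route (a higher number here means more inhibition at the dose given (going by the name of the read-out), a lower number less inhibition), the measured compounds stand as follows:

compound 1 `N#C[C@@H]1CCCN1C(=O)[C@@H]1C[C@H](CO)CN1`: 64%
compound 2 `CN(C)C(=O)C[C@@H]1CN[C@H](C(=O)N2CCC[C@H]2C#N)C1`: 66%
compound 3 `N#C[C@@H]1CCCN1C(=O)[C@@H]1C[C@H](C(=O)N2CCCCCCC2)CN1`: 63%

All three numbers lie within the usual scatter of one another, so compound 3 is not separated from compound 1 or compound 2 on the numbers shown. Compound 4 `CCN(CC)C(=O)[C@@H]1CN[C@H](C(=O)N2CCC[C@H]2C#N)C1` is not yet measured. The change: a group of 5 heavy atoms (4 carbon, 1 nitrogen; no ring) in place of a group of 8 heavy atoms (7 carbon, 1 nitrogen; one eight-membered non-aromatic ring with 1 hetero atom), on a carbonyl carbon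

Among the compounds with values here, the one measured step that touches the same part of the shared core, exchanging the group on the saturated ring carbon, is a number 2 percentage points higher from compound 1 to compound 2 (within the scatter). On that basis the step of no change at the digits printed from compound 3 to compound 4 (within the scatter) is expected to fall within the scatter, with no direction beyond it. Compound 4 is therefore estimated at 63%, in the range 50% to 75%.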

Compound 4, a percentage reported as inhibition, in the whole organism at one dose (the size of the read-out at that dose, not a potency): 43%
Beside the measured number, compound 4's estimate is 20 percentage points above it; the whole stated range lies above it.
By their numbers in this assay, from the lowest: compound 4; then compounds 3, 1 and 2 (each within the scatter of the next).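

Within the data shown here, on a carbonyl carbon, diethylamino in place of the group with the eight-membered non-aromatic ring gives a number 20 percentage points lower from compound 3 to compound 4 (beyond the scatter), the first change to go beyond the scatter in this assay. Against the other groups on the saturated ring carbon, diethylcarbamoyl gives a number 23 percentage points lower from compound 2 to compound 4 (beyond the scatter) from (dimethylcarbamoyl)methyl and a number 21 percentage points lower from compound 1 to compound 4 (beyond the scatter) from hydroxymethyl. No measurement at hand bears on what lies behind these lower numbers. Open, on these data alone, is how dimethylamino or dipropylamino on the same carbonyl carbon would read, and so whether the lower number belongs to diethylamino alone or to open-chain amines on this carbonyl generally.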